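The source may report more compounds than this note shows. Statements on the series, on what has been measured and on what is new or still open speak of the compounds shown alone.

Of the compounds shown here, three of one shared core have been measured in a functional assay on HEK293 cells for agonist activity at Glucose-dependent insulinotropic receptor (Homo sapiens), read by cAMP accumulation, with a stated time of 30 min; on this read-out lower numbers stand for an effect already at smaller amounts and higher numbers for an effect only at larger amounts of compound. Compound 1 `CC(C)OC(=O)N1CCC(n2ncc3cc(-c4ccc(S(C)(=O)=O)cc4)ncc32)CC1` gives 42 nM, compound 2 `CC(C)COC(=O)N1CCC(n2ncc3cc(-c4ccc(S(C)(=O)=O)cc4)ncc32)CC1` gives 11 nM, and compound 3 `CCc1cnc(N2CCC(n3ncc4cc(-c5ccc(S(C)(=O)=O)cc5)ncc43)CC2)nc1` gives 13 nM. Compound 3 thus stands with the second highest of the three numbers: its nearest neighbour is compound 2, with a 1.2-fold higher number from compound 2 to compound 3 (0.07 log units; within the scatter), and its furthest is compound 1, with a 3.2-fold lower number from compound 1 to compound 3 (0.51 log units; beyond the scatter). The other measured step is a 3.8-fold lower number from compound 1 to compound 2 (0.58 log units; beyond the scatter).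

Compound 4 `Cc1ccc(N2CCC(n3ncc4cc(-c5ccc(S(C)(=O)=O)cc5)ncc43)CC2)nc1` differs from compound 3 in one place: 5-methylpyridin-2-yl in place of 5-ethylpyrimidin-2-yl on an amine nitrogen in a ring. Going by the values given here, none of the measured steps touches this pair of aromatic groups. The steps that exist concern the carbamate side chain, as in a 3.8-fold lower number from compound 1 to compound 2 (0.58 log units; beyond the scatter), and the exchange of the carbamate for the pyrimidinyl group, as in a 3.2-fold lower number from compound 1 to compound 3 (0.51 log units; beyond the scatter) and a 1.2-fold higher number from compound 2 to compound 3 (0.07 log units; within the scatter). They show that two rather different groups on the ring nitrogen, in compound 2 and compound 3, give numbers within the scatter of each other, so the ring nitrogen substituent can change without a large shift. The expected step from compound 3 to compound 4 in this assay is therefore a 1.2-fold higher number from compound 3 to compound 4 (0.06 log units; within the scatter), that is, none beyond the scatter. The estimated value for compound 4 in this assay is 15 nM, with a range from 6 nM to 40 nM.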

Compound 4, half-maximal effective concentration: 30 nM
Beside the measured number, compound 4's estimate is 2.0-fold (0.30 log units) below it; the measured number falls inside the stated range.
By their numbers in this assay, from the lowest: compounds 2 and 3 (each within the scatter of the next); then compounds 4 and 1 (each within the scatter of the next).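

Exchanging one aromatic group for another on the amine nitrogen in the ring is not a neutral change in this assay: 5-methylpyridin-2-yl in place of 5-ethylpyrimidin-2-yl gives a 2.3-fold higher number from compound 3 to compound 4 (0.36 log units; beyond the scatter), whereas the earlier compounds had shown only that a carbamate and the pyrimidinyl group could stand within the scatter of each other. The same group also separates from the isobutoxycarbonyl group, with a 2.7-fold higher number from compound 2 to compound 4 (0.44 log units; beyond the scatter), but not from the isopropoxycarbonyl group, with a 1.4-fold lower number from compound 1 to compound 4 (0.15 log units; within the scatter), so this position does respond to the group it carries, and an aromatic ring on the nitrogen does not by itself secure the lower numbers. No measurement at hand accounts for these steps.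

The change from compound 3 to compound 4 alters the ring and the alkyl chain at once, so the compounds shown leave open which of the two carries the step; a 5-methylpyrimidin-2-yl or a 5-ethylpyridin-2-yl group would separate them. Also open, going by these compounds, is how a longer chain, such as 5-propylpyrimidin-2-yl, would behave at this position.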